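Ester side chain variation on the angiotensin receptor series

The source may hold more compounds than are shown below. What is called first, only, known or untested is meant among the compounds shown, and "the series" means these compounds.

Compound 1 `CCCc1nc(CC)c(C(=O)OCC(=O)c2ccccc2)n1Cc1ccc(-c2ccccc2S(=O)(=O)NC(=O)OCCC(C)C)cc1F`: 2 nM
Compound 2 `CCCc1nc(CC)c(C(=O)OCc2ccccc2C(=O)c2ccccc2)n1Cc1ccc(-c2ccccc2S(=O)(=O)NC(=O)OCC(C)C)cc1F`: 1 nM
Compound 3 `CCCc1nc(CC)c(C(=O)OC(C(=O)c2ccccc2)c2ccccc2)n1Cc1ccc(-c2ccccc2S(=O)(=O)NC(=O)OCCC(C)C)cc1F`: 3 nM

Of the compounds shown here, three sharing one core have been tested in an assay on isolated protein for binding affinity to Type-2 angiotensin II receptor (Homo sapiens); a higher number here means a weaker inhibitor, a lower number a stronger inhibitor. Compound 1 stands second highest of the three numbers; its nearest neighbour is compound 3 at a 1.5-fold higher number from compound 1 to compound 3 (0.18 log units; within the scatter), and compound 2 lies furthest, though both values sit within the scatter of compound 1. Compound 4 `CCCc1nc(CC)c(C(=O)OCCN2C(=O)c3ccccc3C2=O)n1Cc1ccc(-c2ccccc2S(=O)(=O)NC(=O)OCCC(C)C)cc1F` differs from compound 1 in one place: a group of 12 heavy atoms (9 carbon, 1 nitrogen, 2 oxygen; one five-membered non-aromatic ring with 1 hetero atom, one six-membered aromatic ring of carbon only) in place of a group of 8 heavy atoms (7 carbon, 1 oxygen; one six-membered aromatic ring of carbon only), on a saturated chain carbon bound to an oxygen next to a carbonyl group. For the measured compounds named here, the only measured step that bears on this region, the step from compound 1 to compound 3, stayed within the scatter, and compound 2, which also varies this side chain, gives a similar value. The expected step in this assay is therefore a 1.5-fold higher number from compound 1 to compound 4 (0.18 log units; within the scatter), no clear direction. Compound 4 is estimated at 3 nM, between 1 nM and 10 nM.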

Compound 4, half-maximal inhibitory concentration: 7 nM
Beside the measured number, compound 4's estimate is 2.3-fold (0.37 log units) below it; the range from low to high includes it.
By their numbers in this assay, from the lowest: compounds 2, 1 and 3 (each within the scatter of the next, the first and the last beyond it); then compound 4.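

In this assay, putting the group of 12 heavy atoms in place of benzoyl gives a 3.5-fold higher number from compound 1 to compound 4 (0.54 log units; beyond the scatter) and is the only step shown at this side chain that lies beyond the scatter; the phenyl change gave only a 1.5-fold higher number from compound 1 to compound 3 (0.18 log units; within the scatter). The position is therefore not indifferent to what it carries, although this step is modest. Nothing available here accounts for the step. Whether the five-membered non-aromatic ring alone accounts for it remains open. So does how an amine, a carboxylic acid or a longer alkyl chain would fare at this place.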